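The source may hold more compounds than are shown below. What is called first, only, known or untested is meant among the compounds shown, and "the series" means these compounds.

Of the compounds shown here, three built on one shared core have been tested in a functional assay on ECa-109 cells (Homo sapiens) for cytotoxicity, read by MTT assay, with a stated time of 48 h; on this read-out lower numbers stand for stronger inhibition and higher numbers for weaker inhibition. Compound 1 `O=C1C(O)=C(C(c2ccc(F)cc2)c2c[nH]c3ccccc23)C(=O)c2ccccc21` gives 28100 nM in this assay. Compound 2 `O=C1C(O)=C(C(c2ccc([N+](=O)[O-])cc2)c2c[nH]c3ccccc23)C(=O)c2ccccc21` gives 60900 nM in this assay, and compound 3 `O=C1C(O)=C(C(c2cccs2)c2c[nH]c3ccccc23)C(=O)c2ccccc21` gives 12100 nM in this assay. Among these three numbers compound 1 stands second highest: the step of a 2.2-fold higher number from compound 1 to compound 2 (0.34 log units; beyond the scatter) and the step of a 2.3-fold lower number from compound 1 to compound 3 (0.37 log units; beyond the scatter) place it between the other two, while a 5.0-fold lower number from compound 2 to compound 3 (0.70 log units; beyond the scatter) spans the whole range.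

Compound 4 `O=C1C(O)=C(C(c2ccc(Cl)cc2)c2c[nH]c3ccccc23)C(=O)c2ccccc21` has not yet been measured in this assay. It differs from compound 1 by chloro in place of fluoro on an aromatic carbon. Among the compounds with values here, only one measured step touches the same place, a 2.2-fold higher number from compound 1 to compound 2 (0.34 log units; beyond the scatter); the steps to compound 3 exchange the whole ring and say little about this swap. That one step was modest, and nothing in these data shows that a chloro group at this place would move the number far in either direction, so a step of about a 1.1-fold lower number from compound 1 to compound 4 (0.05 log units; within the scatter) is expected, within the scatter. Compound 4 is therefore estimated at 25000 nM in this assay, with a likely range from 10000 nM to 60000 nM.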

Compound 4, half-maximal inhibitory concentration: 45800 nM
The estimate for compound 4 lay 1.8-fold (0.26 log units) below the measured number; the range from low to high includes it.
By their numbers in this assay, from the lowest: compound 3; then compounds 1, 4 and 2 (each within the scatter of the next, the first and the last beyond it).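

In this assay, chloro in place of fluoro on this aromatic carbon, para to a large group, gives a step that cannot be told from ordinary repeat variation (a 1.6-fold higher number from compound 1 to compound 4 (0.21 log units; within the scatter)). Chloro and nitro at this place also cannot be separated (a 1.3-fold lower number from compound 2 to compound 4 (0.12 log units; within the scatter)), although fluoro and nitro could be, so compound 4 adds no clear order among these three groups. Exchanging the thiophen-2-yl ring of compound 3 for 4-chlorophenyl gives a step beyond the scatter (a 3.8-fold higher number from compound 3 to compound 4 (0.58 log units; beyond the scatter)), so the thiophen-2-yl compound still gives a lower number than each of the three compounds with a substituted phenyl ring.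

No measurement shown explains any of these differences. From the compounds shown here alone, whether an amine, a carboxylic acid or a methoxy group at this place would move the number beyond the scatter remains open.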